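This account rests on a few compounds, and the source may have more. Where it says the series, first, only, none or still open, it means among the compounds named here.

In a physicochemical assay for solubility, measured as kinetic solubility (on this read-out higher numbers stand for higher solubility and lower numbers for lower solubility), compound 1 `Cc1cnc(NC(=O)c2cc(Oc3cnc(C(=O)N(C)C)cn3)c3cn(C)nc3c2)cn1` gives 192000 nM and compound 2 `Cc1cnc(NC(=O)c2cc(Oc3ccc(S(C)(=O)=O)cc3)c3cn(C)nc3c2)cn1` gives 454000 nM while compound 3 `CCn1cc2c(Oc3ccc(S(C)(=O)=O)cc3)cc(C(=O)Nc3cnc(C)cn3)cc2n1` gives 2100 nM as the lowest of the three numbers. Compound 4 `CCCn1cc2c(Oc3ccc(S(C)(=O)=O)cc3)cc(C(=O)Nc3cnc(C)cn3)cc2n1` differs from compound 3 by one change methyl in place of hydrogen on a saturated chain carbon, two bonds along the chain from an aromatic nitrogen that is methyl in place of hydrogen on a saturated chain carbon, two bonds along the chain from an aromatic nitrogen. Going by the values given here, only one measured step bears on this, methyl in place of hydrogen on a saturated chain carbon bound to an aromatic nitrogen, and it was large with a 220-fold lower number from compound 2 to compound 3 (2.33 log units; beyond the scatter) as its size. That single step sits at a different place, so a smaller move in the same direction is expected in this assay and a 2.6-fold lower number from compound 3 to compound 4 (0.42 log units; beyond the scatter) is the estimated step. For compound 4 the expected value is 800 nM with an estimated range from 150 nM to 3000 nM as its span.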

Compound 4, solubility: 2300 nM
Compound 4: middle estimate off by 2.9-fold (0.46 log units), on the low side; the measured number falls inside the stated range.
By their numbers in this assay, from the lowest: compounds 3 and 4 (each within the scatter of the next); then compound 1; then compound 2.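

In this assay, methyl in place of hydrogen two bonds along the chain from an aromatic nitrogen, the change from ethyl to propyl, gives a 1.1-fold higher number from compound 3 to compound 4 (0.04 log units; within the scatter), so this added carbon makes no difference that can be told from the scatter. The large gap from the methyl-bearing compound remains, with a 200-fold lower number from compound 2 to compound 4 (2.30 log units; beyond the scatter), much like a 220-fold lower number from compound 2 to compound 3 (2.33 log units; beyond the scatter), so at this point it is tied to the carbon bound to the aromatic nitrogen rather than to further chain length. Nothing available here explains these numbers. On these data alone, whether a longer chain such as butyl, or a chain carrying an amine, would follow propyl or depart from it remains open.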